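The source may hold more compounds than are shown below. What is called first, only, known or untested is meant among the compounds shown, and "the series" means these compounds.

In a functional assay (plasma) for inhibition, with Homo sapiens as the target (a higher number here means a weaker inhibitor, a lower number a stronger inhibitor), compound 1 (`O=C(O)CCC/C=C\C[C@@H]1[C@@H](NS(=O)(=O)c2ccc(F)cc2)CC[C@@H]1O`) gives 640 nM, while compound 2 (`Cc1ccc(S(=O)(=O)N[C@@H]2CC[C@@H](O)[C@H]2C/C=C\CCCC(=O)O)cc1`) gives 5800 nM, the higher of the two numbers and beyond the scatter. Compound 3 (`Cc1ccc(S(=O)(=O)N[C@H]2CC[C@H](O)[C@@H]2C/C=C\CCCC(=O)O)cc1`) departs from compound 2 in configuration only: the two compounds have the same atoms and bonds and differ only in configuration as drawn: 3 of 4 stereo elements differ; a stereocentre at a saturated ring carbon is drawn R in compound 2 and S in compound 3; a stereocentre at a saturated ring carbon is drawn R in compound 2 and S in compound 3; a stereocentre at a saturated ring carbon is drawn S in compound 2 and R in compound 3. Going by the values given here, no measured step covers such a change, but a large move to a lower number, beyond the scatter, is expected in this assay, with compound 1 at 640 nM as the guide. The expected change is an 8.3-fold lower number from compound 2 to compound 3 (0.92 log units; beyond the scatter). Compound 3 is estimated at 700 nM, with an expected range of 200 nM to 3000 nM.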

Compound 3, half-maximal inhibitory concentration: 500 nM
For compound 3 the middle estimate is 1.4-fold (0.15 log units) above the measured one; measured number inside the range.
By their numbers in this assay, from the lowest: compounds 3 and 1 (each within the scatter of the next); then compound 2.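

In this assay, configuration alone carries a large step, a 12-fold lower number from compound 2 to compound 3 (1.06 log units; beyond the scatter). This step can be assigned to the drawn stereocentres on the saturated ring carbons and to nothing else: the fact that compounds 2 and 3 differ only in the configuration as drawn. With that configuration in place, methyl in place of fluoro on an aromatic carbon stays within the scatter, a 1.3-fold lower number from compound 1 to compound 3 (0.11 log units; within the scatter).

Which of the three changed stereocentres carries the step remains open. Also open, on these data alone, is how a chloro or methoxy group on that aromatic carbon would read in this assay.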